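Compound 4: 3-chlorophenyl replacing 2-methylphenyl

The source may hold more compounds than are shown below. What is called first, only, known or untested is meant among the compounds shown, and "the series" means these compounds.

Measured in a functional assay on SGC-7901 cells (Homo sapiens) for antiproliferative activity, read by MTT assay, with a stated time of 24 h; on this read-out higher numbers stand for weaker inhibition and lower numbers for stronger inhibition:
Compound 1 `O=C(NNc1cccc(Cl)c1)c1cccc(NS(=O)(=O)c2cnc(O)nc2O)c1`: 11800 nM
Compound 2 `O=C(NNc1ccc(F)cc1)c1cccc(NS(=O)(=O)c2cnc(O)nc2O)c1`: > 20000 nM, a limit
Compound 3 `Cc1ccccc1NNC(=O)c1ccccc1NS(=O)(=O)c1cnc(O)nc1O`: > 20000 nM, a limit

Compound 3 gives only a limit, (the limit of > 20000 nM in this assay, at which 2 of the 3 values shown sit). Compound 4 `O=C(NNc1cccc(Cl)c1)c1ccccc1NS(=O)(=O)c1cnc(O)nc1O` differs from it by 3-chlorophenyl in place of 2-methylphenyl on an amine nitrogen, with 3-chlorophenyl in place of 2-methylphenyl on an amine nitrogen. Within the data shown here, the only measured step touching this group is an at least 1.6-fold higher number from compound 1 to compound 2 (0.22 log units; that floor lies within the scatter). Its floor lies within the scatter, and it was taken on the core of compound 1, not that of compound 3. Compound 1, which carries the same 3-chlorophenyl, gives 11800 nM, so a modest shift toward stronger inhibition is expected. The estimated step is an at least 1.4-fold lower number from compound 3 to compound 4 (0.15 log units; that floor lies within the scatter), and another limit remains possible. The expected value for compound 4 is 14000 nM, with an estimated range of 6000 nM to 30000 nM.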

Compound 4, half-maximal inhibitory concentration: 10800 nM
Compound 4: middle estimate off by 1.3-fold (0.11 log units), on the high side; measured number inside the range.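

In this assay there is an at least 1.8-fold lower number from compound 3 to compound 4 (0.26 log units; that floor lies within the scatter) on going to 3-chlorophenyl on the amine nitrogen, so this group now gives a measured number on a second core. That step is only a floor, as compound 3 remains a limit: the limit of > 20000 nM in this assay, at which 2 of the 4 values shown sit. Compound 1 gives 11800 nM and compound 4 gives 10800 nM on their two cores, values within the usual scatter of each other.

Open, on these data alone, is whether any aryl group on this nitrogen gives a step beyond the scatter. Also open, as far as these compounds go, is how an amine or a carboxylic acid in place of the chlorine would read.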